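A few compounds are considered here, and "the series" means these few. Any claim that something is new, unique, unknown or untested is made for them only; others in the source may bear on it.

Working notes on the series. Within the data shown here, compound 2 `CCS(=O)(=O)Nc1cccc2c1CCCC2c1c[nH]cn1` is the lower of the two numbers so far in an assay on isolated protein for binding affinity to Alpha-1A adrenergic receptor (Rattus norvegicus), read by radioligand binding; a higher number here means a weaker inhibitor, a lower number a stronger inhibitor: compound 2 gives 46.8 nM, whereas compound 1 `CCCS(=O)(=O)Nc1cccc2c1CCCC2c1c[nH]cn1` gives 1700 nM. Among the measured compounds shown here, the only measured step is a 36-fold lower number from compound 1 to compound 2 (1.56 log units; beyond the scatter), which shows that the group on the ring nitrogen is not a neutral position in this assay.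

Compound 3 `CC(=O)Nc1cccc2c1CCCC2c1c[nH]cn1` is the next member. Compared with compound 2 the change is acetyl in place of ethylsulfonyl on a nitrogen on an aromatic ring. For the measured compounds named here, no measured step exchanges the sulfonyl for a carbonyl, so the single step between compound 1 and compound 2 bears on this only indirectly: it shows that trimming the group on that nitrogen moved the number a long way, but the trimming there kept the sulfonyl intact, which is not the case here. A step of moderate size in either direction is plausible, and the range must be wide.

Working estimate: compound 3 is expected to give 150 nM in this assay, within 30 nM to 800 nM, which means an expected step of a 3.2-fold higher number from compound 2 to compound 3 (0.51 log units; beyond the scatter).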

Compound 3, inhibition constant: 525 nM
Compound 3: middle estimate off by 3.5-fold (0.54 log units), on the low side; the range from low to high includes it.
By their numbers in this assay, from the lowest: compound 2; then compound 3; then compound 1.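

In this assay, acetyl in place of ethylsulfonyl on a nitrogen on an aromatic ring gives an 11-fold higher number from compound 2 to compound 3 (1.05 log units; beyond the scatter), so this position responds to the exchange of the whole group as well as to trimming of the sulfonyl chain. Acetyl in place of propylsulfonyl at the same nitrogen runs the other way, with a 3.2-fold lower number from compound 1 to compound 3 (0.51 log units; beyond the scatter), so the sulfonyl-bearing compounds do not sit together on one side of the acetyl compound: ethylsulfonyl gives the lower number and propylsulfonyl the higher, and the direction of the exchange depends on which sulfonyl group leaves. Nothing available gives a measured reason for either step.

The compounds shown leave open whether methylsulfonyl would continue the trend seen from propylsulfonyl to ethylsulfonyl or reverse it. They also leave open whether a propionyl group in place of acetyl would move the number as strongly as the added methyl does in the sulfonyl pair, and how a free amine on the same aromatic ring would compare with all three.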